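The source may report more compounds than this note shows. Statements on the series, on what has been measured and on what is new or still open speak of the compounds shown alone.

Compound 3 `CCCCCCCN(CCCCCSc1[nH]cnc2ncnc1-2)C(=O)NC(C)C` gives the highest number of the three compounds measured in an assay on microsomes from liver for inhibition of sterol O-acyltransferase 1 (Rattus norvegicus) (on this read-out lower numbers stand for stronger inhibition and higher numbers for weaker inhibition), at 29700 nM. Within the data shown here, compound 2 `CCCCCCCN(CCCCCSc1[nH]cnc2ncnc1-2)C(=O)Nc1ccc(F)cc1F` gives 200 nM, and the step of a 150-fold higher number from compound 2 to compound 3 (2.17 log units; beyond the scatter) is the only single-point change measured. Among the measured compounds shown here, compound 1 `CCCCCCN(CCCCCSc1nc2ccc[nH]c-2n1)C(=O)Nc1ccc(F)cc1F` gives 3600 nM; it differs from compound 2 in more than one place, so its values show only that this pair lies apart. Compound 4 `CCCCCCCN(CCCCCSc1[nH]cnc2nncc1-2)C(=O)NC(C)C` differs from compound 3 by a group of 9 heavy atoms (5 carbon, 4 nitrogen; one five-membered aromatic ring with 2 hetero atoms, one six-membered aromatic ring with 2 hetero atoms) in place of a group of 9 heavy atoms (5 carbon, 4 nitrogen; one five-membered aromatic ring with 2 hetero atoms, one six-membered aromatic ring with 2 hetero atoms), on a sulfur, a rearrangement of the same atoms. For the measured compounds named here, no measured step bears on this change, so no shift beyond the scatter is expected, and compound 4 is estimated at 30000 nM (range 10000 nM to 90000 nM), a step of a 1.0-fold higher number from compound 3 to compound 4 (0.00 log units; within the scatter) expected from compound 3.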

Compound 4, half-maximal inhibitory concentration: 7130 nM
Compound 4: the middle estimate sits 4.2-fold (0.62 log units) above what was measured; the whole stated range lies above it.
By their numbers in this assay, from the lowest: compound 2; then compounds 1 and 4 (each within the scatter of the next); then compound 3.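

In this assay, rearranging the atoms of the group on the sulfur gives a 4.2-fold lower number from compound 3 to compound 4 (0.62 log units; beyond the scatter), with the counted atoms, donors and acceptors unchanged. Among these compounds, this position therefore responds to how the same atoms are joined, which the earlier compounds did not show. Nothing given here accounts for the shift.

Going by these compounds, it remains open whether the rearrangement would have a similar effect with the 2,4-difluorophenyl group of compound 2 in place of isopropyl. Also open, on these data alone, is how an amine or a carboxylic acid on the group attached to the sulfur would read.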